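A few compounds are considered here, and "the series" means these few. Any claim that something is new, unique, unknown or untested is made for them only; others in the source may bear on it.

The measured compounds:
Compound 1, `COCOc1cc(/C=C/C(=O)OCC(=O)NCc2ccco2)ccc1OCc1ccccc1`, in a functional assay on ECa-109 cells (Homo sapiens) for cytotoxicity, read by MTT assay, with a stated time of 72 h (a lower number here means a stronger inhibitor, a higher number a weaker inhibitor), gives > 200000 nM, which is a limit of the assay and not a number.
Compound 2, `COc1ccc(NC(=O)COC(=O)/C=C/c2cc(OC)c(OCc3ccc(Cl)c(Cl)c3)c(OC)c2)cc1`, in this assay gives > 200000 nM, also a limit.
Compound 3, `CCOc1ccc(COc2c(OC)cc(/C=C/C(=O)N3CCN(Cc4ccc(Cl)c(Cl)c4)CC3)cc2OC)cc1`, in this assay gives 1100 nM.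

Compound 1 therefore stands at the limit, as the limit of > 200000 nM in this assay, at which 2 of the 3 values shown sit, records, and only compound 3 gives a number. The unmeasured compound 4, `COCOc1cc(/C=C/C(=O)OCC(=O)Nc2ccc(OC)cc2)ccc1OCc1ccccc1`, differs from compound 1 in one place: 4-methoxyphenyl in place of (furan-2-yl)methyl on an amide-type nitrogen. Among the measured compounds shown here, no step between measured compounds is available, so the size of this change cannot be read off directly. Compound 2 carries the same 4-methoxyphenyl on its amide nitrogen and gives > 200000 nM, a limit. On that basis compound 4 is expected to remain at the limit, so a step that the limit leaves unreadable from compound 1 to compound 4 is expected to be no step beyond the scatter. The estimate for compound 4 is 250000 nM, between 100000 nM and 600000 nM.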

Compound 4, half-maximal inhibitory concentration: > 200000 nM
Compound 4 gave a limit, no number; the forecaster's own chance of this, stated with the estimate: 85%; the middle value is on the limit's open side.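

Compound 1 and compound 4 both stay at a limit in this assay, not at a number, so no step can be read between them: the limit of > 200000 nM in this assay, at which 3 of the 4 values shown sit.

The compounds shown leave open whether 4-methoxyphenyl in place of (furan-2-yl)methyl on an amide-type nitrogen changes the activity at all.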